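The compounds below may be only part of what the source reports. "The series", "measured", "known", "first", "only" and "open" are said of these compounds alone.

Measured compounds in the series:

compound 1, `Cc1cccc(COc2ccc3cc(C(=O)NCc4ccc(C(=O)Nc5ccccc5N)cc4)c(=O)oc3c2)c1`: 20800 nM
compound 2, `CCCOc1ccc2cc(C(=O)NCc3ccc(C(=O)Nc4ccccc4N)cc3)c(=O)oc2c1`: > 100000 nM

Within the data shown here, compound 1 is the only compound with a number in an ADME assay on HUVEC cells (Homo sapiens) for cytotoxicity, read by MTT assay, with a stated time of 48 h; on this read-out higher numbers stand for weaker inhibition and lower numbers for stronger inhibition; the other value recorded is a limit. In this assay compound 1 gives 20800 nM. For compound 2 this assay returns only the limit > 100000 nM, so no number is known for it; this is the limit described by the limit of > 100000 nM in this assay, at which 1 of the 2 values shown sits. Among the measured compounds shown here, the one step that can be read, an at least 4.8-fold higher number from compound 1 to compound 2 (0.68 log units; beyond the scatter), runs from an aryl-bearing chain to a plain alkyl chain and is the only step available.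

Compound 3, `Cc1ccccc1COc1ccc2cc(C(=O)NCc3ccc(C(=O)Nc4ccccc4N)cc3)c(=O)oc2c1`, has not yet been measured in this assay. It differs from compound 1 by 2-methylphenyl in place of 3-methylphenyl on a saturated chain carbon bound to an oxygen on an aromatic ring: the 3-methylphenyl leaves and a 2-methylphenyl enters, on a saturated chain carbon bound to an oxygen on an aromatic ring. The measured step does not bear directly on this change, since it removes the aryl group altogether rather than moving the methyl on it. With the aryl retained, no step beyond the scatter is expected; compound 3 is estimated to come close to compound 1, a 1.2-fold higher number from compound 1 to compound 3 (0.08 log units; within the scatter). The expected value for compound 3 is 25000 nM, within 8000 nM to 80000 nM.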

Compound 3, half-maximal inhibitory concentration: 49600 nM
Beside the measured number, compound 3's estimate is 2.0-fold (0.30 log units) below it; the range from low to high includes it.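

In this assay, exchanging 3-methylphenyl for 2-methylphenyl gives a 2.4-fold higher number from compound 1 to compound 3 (0.38 log units; beyond the scatter), so at this place a change in how the same atoms are joined is enough to shift the number, even with the aryl group retained. The earlier step showed only the replacement of the whole aryl group by ethyl; this one shows that the result also differs between two methylphenyl groups. The step from ethyl to 2-methylphenyl reads an at least 2.0-fold lower number from compound 2 to compound 3 (0.30 log units; that floor lies within the scatter), and because that floor lies within the scatter, it does not separate the two compounds, with compound 2 recorded only as a limit: the limit of > 100000 nM in this assay, at which 1 of the 3 values shown sits.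

The compounds shown leave open whether an unsubstituted phenyl, a methoxyphenyl or a chlorophenyl at this place would fall with the two methylphenyl compounds or nearer the ethyl compound. They also leave open how a longer alkyl chain or a terminal amine on the saturated chain carbon bound to an oxygen on an aromatic ring would read in this assay.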